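Swapping methylsulfonyl for hydroxy on an amide nitrogen

A few compounds are considered here, and "the series" means these few. Any claim that something is new, unique, unknown or untested is made for them only; others in the source may bear on it.

In a functional assay on MOLM-13 cells (Homo sapiens) for antiproliferative activity (a higher number here means a weaker inhibitor, a lower number a stronger inhibitor), three compounds that share one core have been measured, and they differ only in the group on a single aromatic carbon. Compound 1 (`Cc1c(-c2ccc(-c3ccccc3F)cc2)nc2ccc(F)cc2c1C(F)F`) carries difluoromethyl and reads > 3000 nM as a limit of the assay, not a number. Compound 2 (`Cc1c(-c2ccc(-c3ccccc3F)cc2)nc2ccc(F)cc2c1C(O)C(F)(F)F`) carries 2,2,2-trifluoro-1-hydroxyethyl and gives 640 nM as a measured number. Compound 3 (`Cc1c(-c2ccc(-c3ccccc3F)cc2)nc2ccc(F)cc2c1C(=O)NS(C)(=O)=O`) carries (methylsulfonyl)carbamoyl and stands lowest of the three at 300 nM with both gaps beyond the usual scatter.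

Three measured steps at that carbon set the scale, namely an at least 4.6-fold lower number from compound 1 to compound 2 (0.67 log units; beyond the scatter) as well as an at least 10-fold lower number from compound 1 to compound 3 (1.00 log units; beyond the scatter) and a 2.1-fold lower number from compound 2 to compound 3 (0.33 log units; beyond the scatter) in the same direction. Compound 4 (`Cc1c(-c2ccc(-c3ccccc3F)cc2)nc2ccc(F)cc2c1C(=O)NO`) keeps the carbonyl of compound 3 but has hydroxy in place of methylsulfonyl on the amide-type nitrogen (hydroxy in place of methylsulfonyl on an amide-type nitrogen). Going by the values given here, no measured pair makes this exact change, so the guidance is indirect. Compound 3 already holds the lowest number (300 nM), so a modest step back up is expected, close in size to a 2.1-fold lower number from compound 2 to compound 3 (0.33 log units; beyond the scatter) but in the opposite direction. The estimated step in this assay is a 2.3-fold higher number from compound 3 to compound 4 (0.37 log units; beyond the scatter) with considerable doubt about its size. For compound 4 the estimate is 700 nM with an expected range from 150 nM to 3000 nM on this evidence.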

Compound 4, half-maximal inhibitory concentration: 23 nM
The estimate for compound 4 lay 30-fold (1.48 log units) above the measured number; the measured number lies below the stated range.
By their numbers in this assay, from the lowest: compound 4; then compound 3; then compound 2. At a limit, above all of these: compound 1.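

In this assay, keeping the carbonyl and placing hydroxy in place of methylsulfonyl on the amide-type nitrogen gives a 13-fold lower number from compound 3 to compound 4 (1.12 log units; beyond the scatter) and so shows that this position responds strongly to what sits on that nitrogen, not merely to the presence of a carbonyl. Hydroxycarbamoyl in place of 2,2,2-trifluoro-1-hydroxyethyl gives a 28-fold lower number from compound 2 to compound 4 (1.44 log units; beyond the scatter) and is a far larger change between two measured numbers than the modest one the earlier compounds had shown, which leaves compound 4 with the lowest number of the series. Hydroxycarbamoyl in place of difluoromethyl gives an at least 130-fold lower number from compound 1 to compound 4 (2.11 log units; beyond the scatter) as a minimum size only, because the reading for compound 1 is a limit of the assay and not a number: the limit of > 3000 nM in this assay, at which 1 of the 4 values shown sits.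

From the compounds shown here alone, how a carboxylic acid on the same aromatic carbon, or methoxy on the same amide-type nitrogen, would read remains open, so these compounds cannot show whether the hydroxy itself or the whole hydroxycarbamoyl group carries the change. Whether the same order among these compounds would hold in any cells other than those of this one assay also stays unanswered.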